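Bromo for Hydrogen on the Furan-2-yl Group

This account rests on a few compounds, and the source may have more. Where it says the series, first, only, none or still open, it means among the compounds named here.

Compound 1, `N#C/C(=C\c1ccc(Cl)cc1)C(=O)c1ccc[nH]1`: 52000 nM
Compound 2, `COc1ccc(CNC(=O)/C(C#N)=C/c2ccco2)cc1`: 16000 nM
Compound 3, `N#C/C(=C\c1ccco1)C(=O)NCc1ccc(Cl)c(Cl)c1`: a limit, > 50000 nM

In a functional assay on A-431 cells (Homo sapiens) for inhibition, read by MTT assay, with a stated time of 72 h (on this read-out lower numbers stand for stronger inhibition of growth and higher numbers for weaker inhibition of growth), compound 2 gives 16000 nM, the lowest of the two numbers measured. Compound 1, with 52000 nM, is the nearest number, and the gap between the two lies beyond the usual scatter of repeated measurements. For compound 3 this assay reports only a limit, > 50000 nM; this is the limit of > 50000 nM in this assay, at which 1 of the 3 values shown sits.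

Compound 4, `COc1ccc(CNC(=O)/C(C#N)=C/c2ccc(Br)o2)cc1`, is compound 2 with one change: bromo in place of hydrogen on an aromatic carbon. Going by the values given here, no pair of measured compounds differs by this change, so there is no measured step to lean on. The three measured compounds differ from one another in more than one place and show only that the shared amide series, with compound 2, reaches a lower number than compound 1, while compound 3 is at the limit.

Given the small size of the change, compound 4 is expected to sit close to compound 2, with a step of a 1.3-fold lower number from compound 2 to compound 4 (0.12 log units; within the scatter) that is estimated to fall within the scatter in this assay. The estimate for compound 4 is 12000 nM, with a range from 4000 nM to 40000 nM.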

Compound 4, concentration for 50% growth inhibition: 9000 nM
Compound 4: the middle estimate sits 1.3-fold (0.12 log units) above what was measured; low and high end bracket the measured number.
By their numbers in this assay, from the lowest: compounds 4 and 2 (each within the scatter of the next); then compound 1.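

Going by these compounds alone, the change from furan-2-yl to 5-bromofuran-2-yl gives the first step in this set between two compounds that differ in one place, and in this assay it reads a 1.8-fold lower number from compound 2 to compound 4 (0.25 log units; within the scatter) and so stays inside what repeated measurements would show. This aromatic carbon, next to the ring oxygen and two ring bonds from the ring atom that bears a large group, therefore carries a bromo, a single heavy atom, and the two numbers cannot be told apart on this read-out. Nothing measured here gives a property of the bromo group or accounts for the size of this step.

The compounds shown leave open whether another group at this place, such as an amine, a carboxylic acid or a longer chain, would move the number beyond the scatter, as a single replacement gives no trend. Going by these compounds, compound 3 stands at a limit, > 50000 nM, and whether bromo on its furan-2-yl group would bring it to a measurable number also remains open.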